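This account rests on a few compounds, and the source may have more. Where it says the series, first, only, none or still open, it means among the compounds named here.

Compound 1 `COc1ccc(C)cc1NC(=S)N/N=C/c1ccc2ccccc2n1`: in a functional assay on SGC-7901 cells (Homo sapiens) for antiproliferative activity, read by sulforhodamine B assay, with a stated time of 72 h (a higher number here means a weaker inhibitor, a lower number a stronger inhibitor), compound 1 gives > 100000 nM, a limit of the assay rather than a number.
Compound 2 `Cc1cccc(NC(=S)N/N=C/c2ccc3ccccc3n2)c1`: in this assay compound 2 gives > 100000 nM, again a limit of the assay rather than a number.

Compound 2 therefore stands at the edge of what this assay can report: the assay returns only a limit, and compound 1 sits at the same place, so both values fall at the limit of > 100000 nM in this assay, at which 2 of the 2 values shown sit. Among the measured compounds shown here, the single measured step, a step that the two limits leave unreadable from compound 1 to compound 2, has a limit at each end and so tells neither its size nor its direction.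

Compound 3 `NC(=S)N/N=C/c1ccc2ccccc2n1` differs from compound 2 in one place: hydrogen in place of 3-methylphenyl on an amide-type nitrogen. For the measured compounds named here, no measured step bears on this particular change, and the one step that exists is unreadable, so there is nothing to suggest a move in this assay beyond the scatter in either direction. Compound 3 is therefore expected to come back at a limit as well, estimated at about 100000 nM, with a range from 30000 nM to 300000 nM. The step this estimate implies, a number no higher from compound 2 to compound 3 (the limit leaves the size open), is expected to be no more than the scatter.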

Compound 3, half-maximal inhibitory concentration: 32700 nM
The estimate for compound 3 lay 3.1-fold (0.49 log units) above the measured number, within the range that was stated.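

In this assay, putting hydrogen in place of the 3-methylphenyl on the amide-type nitrogen gives an at least 3.0-fold lower number from compound 2 to compound 3 (0.48 log units; beyond the scatter), so a change at this position can be read, and it runs toward a stronger inhibitor. Among the compounds shown here, compound 3, at 32700 nM, is the first compound here with an actual number rather than a limit, which gives later comparisons at this nitrogen a measured point to start from. The 3-methylphenyl group is therefore not needed for the activity of compound 3, although the step is only a minimum and the other values remain at the edge of what the assay reports: the limit of > 100000 nM in this assay, at which 2 of the 3 values shown sit.

The compounds shown leave open how activity changes between the two extremes of hydrogen and 3-methylphenyl, since a small methyl, a longer chain such as butyl, or a benzyl group on this nitrogen could fall anywhere relative to compound 3. They also cannot say why removing the 3-methylphenyl lowers the number, or whether an amine or a carboxylic acid carried on such a chain would lower it further.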